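Chlorinated Heteroaryl Compounds in a Cytotoxicity Assay

This account rests on a few compounds, and the source may have more. Where it says the series, first, only, none or still open, it means among the compounds named here.

Measured in a functional assay on DU-145 cells (Homo sapiens) for cytotoxicity, read by ELISA, with a stated time of 4 days; a higher number here means a weaker inhibitor, a lower number a stronger inhibitor:
- compound 1 `Cc1ccc(-c2cc(-c3ccoc3)cc(-c3ccc(Cl)s3)n2)cc1`: 25300 nM
- compound 2 `Cc1ccsc1-c1cc(-c2ccc(Cl)o2)cc(-c2ccco2)n1`: 27300 nM
- compound 3 `Clc1ccc(-c2cc(-c3ccco3)nc(-c3ccc(Cl)s3)c2)o1`: 27700 nM

At 27700 nM, compound 3 lies within the scatter of both compound 1 and compound 2, so the three values give no ranking. The next compound, compound 4 `Cc1ccc(-c2cc(-c3ccc(Cl)o3)cc(-c3ccc(Cl)s3)n2)cc1`, has not yet been measured. It carries 4-methylphenyl in place of furan-2-yl on an aromatic carbon, next to the ring nitrogen: 4-methylphenyl in place of furan-2-yl on an aromatic carbon.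

Within the data shown here, only one measured step connects compounds that differ in a single place, and it concerns a different replacement: a 1.0-fold higher number from compound 2 to compound 3 (0.01 log units; within the scatter). It shows no change beyond the scatter. The same 4-methylphenyl group is present in compound 1, which gives 25300 nM, a value within the scatter of that of compound 3. Among the measured compounds shown here, no measured pair isolates the replacement itself, so this evidence is indirect. Even so, no shift beyond the scatter is expected in this assay, and no direction is favoured. The expected change is a 1.1-fold lower number from compound 3 to compound 4 (0.04 log units; within the scatter). For compound 4, the estimated value is 25000 nM, with an expected range from 12500 nM to 50000 nM.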

Compound 4, half-maximal inhibitory concentration: > 50000 nM
Compound 4 gave a limit, no number; the forecaster's own chance of this, stated with the estimate: 10%; middle value at least 2.0-fold (0.30 log units) away from the limit.
By their numbers in this assay, from the lowest: compounds 1, 2 and 3 (each within the scatter of the next). At a limit, above all of these: compound 4.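

In this assay compound 4 gives no number but a limit: the limit of > 50000 nM in this assay, at which 1 of the 4 values shown sits.

With 4-methylphenyl in place of furan-2-yl on the aromatic carbon next to the ring nitrogen, the result is an at least 1.8-fold higher number from compound 3 to compound 4 (0.25 log units; that floor lies within the scatter), and with 5-chlorofuran-2-yl in place of furan-3-yl on an aromatic carbon, it is an at least 1.9-fold higher number from compound 1 to compound 4 (0.29 log units; that floor lies within the scatter). Both steps are floors only, and both floors lie within the scatter, so neither change is shown to matter beyond it; what is new is that these steps, unlike the one step among the earlier compounds, have no upper end, and that sharing the 4-methylphenyl group with compound 1 does not give compound 4 a number in this assay.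

As far as these compounds go, the actual value of compound 4 stays open, and with it whether either step goes beyond the scatter at all. Also open, from the compounds shown here alone, is whether an amine or a carboxylic acid on the 4-methylphenyl ring, or a longer chain in place of its methyl, would return a number in this assay.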